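Moving the Bromine on the Anilide End

This account rests on a few compounds, and the source may have more. Where it says the series, first, only, none or still open, it means among the compounds named here.

Compound 1 `O=C(CCCCCCNC(=O)C(O)(O)C(F)(F)F)Nc1ccc(Br)cc1`: 3130 nM
Compound 2 `O=C(CCCCCCNC(=O)C(O)(O)C(F)(F)F)Nc1ccc(C(=O)c2ccccc2)cc1`: > 40000 nM (a limit)

Among the measured compounds shown here, in a functional assay on HCT-116 cells (Homo sapiens) for inhibition, read by colorimetric assay, with a stated time of 3 days (on this read-out lower numbers stand for stronger inhibition and higher numbers for weaker inhibition), compound 1 gives 3130 nM, the only exact number available so far. For compound 2 the assay reports a limit, > 40000 nM, and not a number.

The next compound to be tested is compound 3 `O=C(CCCCCCNC(=O)C(O)(O)C(F)(F)F)Nc1cccc(Br)c1`, which has the same atoms as compound 1, joined differently: 3-bromophenyl in place of 4-bromophenyl on an amide-type nitrogen.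

For the measured compounds named here, only one measured step bears on this change, and it does so indirectly: an at least 12-fold higher number from compound 1 to compound 2 (1.10 log units; beyond the scatter). That step is large and beyond the scatter, but it puts benzoyl in place of bromo, whereas compound 3 retains the bromine. Going by the values given here, no measured step shows what moving the bromine does, so the range has to stay wide.

An estimated step of a 1.3-fold higher number from compound 1 to compound 3 (0.11 log units; within the scatter) is expected, which would not go beyond the scatter in this assay. For compound 3 the expected value is 4000 nM, with an estimated range of 1400 nM to 13000 nM.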

Compound 3, half-maximal inhibitory concentration: 3060 nM
Compound 3: the middle estimate sits 1.3-fold (0.12 log units) above what was measured; the range from low to high includes it.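

In this assay, moving the bromine gives a 1.0-fold lower number from compound 1 to compound 3 (0.01 log units; within the scatter), so on this read-out 3-bromophenyl and 4-bromophenyl on the amide-type nitrogen cannot be told apart. Among the compounds shown here, this is the first comparison in which the bromine stays and only its place on the phenyl ring changes, which separates the question of where the bromine sits from the question of which group is present. Compound 2, which carries benzoyl in place of bromo, gives a limit and not a number: the limit of > 40000 nM in this assay, at which 1 of the 3 values shown sits.

Among these three compounds, then, exchanging the group has gone with a large step, while moving the bromine has not, but a single pair cannot show whether that holds for other groups on this ring. As far as these compounds go, it remains open whether moving an amine or a methoxy group on the phenyl ring would also leave the number within the scatter, and whether a longer chain would change the number for either bromophenyl compound.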